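Swapping the side chain of compound 3

This account rests on a few compounds, and the source may have more. Where it says the series, first, only, none or still open, it means among the compounds named here.

Results so far in an ADME assay on BJ cells (Homo sapiens) for cytotoxicity, with a stated time of 72 h; a lower number here means that less compound is needed, a higher number that more compound is needed for the effect:
- Compound 1 `COc1cc2ncnc(-n3nc(-c4ccccn4)nc3N)c2cc1N` has "not determined" (no result reported) as its entry
- Compound 2 `COc1cc2ncnc(-n3nc(-c4ccccn4)nc3N)c2cc1OCc1ccccc1` gives > 27000 nM as a limit
- Compound 3 `CCN(CC)C(=O)COc1cc2c(-n3nc(-c4ccccn4)nc3N)ncnc2cc1OC` gives > 25000 nM as a limit

Compound 3 stands only at a limit (> 25000 nM), with no exact number known. Compound 4 `COc1cc2ncnc(-n3nc(-c4ccccn4)nc3N)c2cc1OCCCCNC(=O)OC(C)(C)C` carries 3-((tert-butoxycarbonyl)amino)propyl in place of diethylcarbamoyl, a change counted as 3-((tert-butoxycarbonyl)amino)propyl in place of diethylcarbamoyl on a saturated chain carbon bound to an oxygen on an aromatic ring on the same shared core. Among the compounds with values here, the one measured step at this place is a step that the two limits leave unreadable from compound 2 to compound 3 with limits at both ends. No step beyond the scatter is therefore expected in this assay, and compound 4 will probably also return only a limit. The expected change is a number no higher from compound 3 to compound 4 (the limit leaves the size open) as an estimate. Compound 4 is estimated at about 25000 nM, with an expected range from 12000 nM to 50000 nM in this measurement.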

Compound 4, half-maximal effective concentration: > 7000 nM
Compound 4 gave a limit, no number; the forecaster's own chance of this, stated with the estimate: 80%; the middle value lies beyond the limit too.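

In this assay, within the data shown here, compound 2, compound 3 and compound 4 each return only a limit, not a number, so no step between them can be read. On these data alone, whether their side chains change the result at all remains open.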